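A few compounds are considered here, and "the series" means these few. Any claim that something is new, unique, unknown or untested is made for them only; others in the source may bear on it.

Measured so far:
compound 1, `Clc1[nH]ccc2ncnc1-2`, 6%
compound 2, `OCCNc1[nH]ccc2ncnc1-2`, 3%
compound 3, `OC[C@H]1OC(n2cnc3c(NCc4ccccc4)nccc32)[C@H](O)[C@@H]1O`, 32%

In a functional assay (Homo sapiens) for inhibition of Nucleic Acid, tested at 100 uM (a higher number here means more inhibition at the concentration tested (going by the name of the read-out), a lower number less inhibition), compound 2 gives the lowest of the three numbers. Its nearest neighbour is compound 1; the step of a number 3 percentage points lower from compound 1 to compound 2 (within the scatter) lies within the scatter, so the two read as alike. Going by the values given here, compound 3 stands furthest away, with a higher number beyond the scatter, but no single-point step connects it to compound 2.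

Compound 4, `CNc1[nH]ccc2ncnc1-2`, is not yet measured. It differs from compound 2 as follows: hydrogen in place of hydroxymethyl on a saturated chain carbon bound to a nitrogen on an aromatic ring. Among the compounds with values here, the one measured step at this nitrogen, a number 3 percentage points lower from compound 1 to compound 2 (within the scatter), swapped the whole substituent and still stayed within the scatter. Within the data shown here, no step shows that trimming this chain moves this assay at all. The expectation for compound 4 is therefore a step of a number 2 percentage points higher from compound 2 to compound 4 (within the scatter), none beyond the scatter. Compound 4 is estimated at 5%, in a range from 0% to 15%.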

Compound 4, a percentage reported as inhibition, at one concentration (the size of the read-out at that concentration, not a potency): 18%
For compound 4 the middle estimate is 13 percentage points below the measured one; measured number outside the range, above it.
By their numbers in this assay, from the lowest: compounds 2 and 1 (each within the scatter of the next); then compound 4; then compound 3.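

In this assay, the substituent on this nitrogen is not silent: the change from (2-hydroxyethyl)amino to methylamino gives a number 15 percentage points higher from compound 2 to compound 4 (beyond the scatter), although the earlier swap of chloro for (2-hydroxyethyl)amino, a number 3 percentage points lower from compound 1 to compound 2 (within the scatter), had left the read-out within the scatter. Methylamino also separates from chloro, with a number 12 percentage points higher from compound 1 to compound 4 (beyond the scatter), so compound 4 stands apart from both compound 1 and compound 2, which remain alike. Nothing at hand bears on the cause of these steps.

The compounds shown leave open whether the step follows the loss of the hydroxyl or the shorter chain; an ethylamino group, which keeps the chain and drops the hydroxyl, would separate the two. A plain amine or a dimethylamino group in the same place would show how far the read-out follows the size of the substituent.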